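The source may report more compounds than this note shows. Statements on the series, on what has been measured and on what is new or still open speak of the compounds shown alone.

Of the compounds shown here, three built on one shared core have been measured for how strongly they hold back the growth of a breast-cancer cell line. Compound 1 `COc1cc(C=c2s/c(=C3\C(=O)Nc4ccc(F)cc43)n(CCN(C)C)c2=O)cc(OC)c1OC` gives 1900 nM in a functional assay on MDA-MB-231 cells (Homo sapiens) for inhibition, read by MTT assay, with a stated time of 72 h; a higher number here means a weaker inhibitor, a lower number a stronger inhibitor. Compound 3 `CN(C)CCn1c(=O)c(=Cc2ccc(F)c(F)c2)s/c1=C1\C(=O)Nc2cc(F)ccc21` gives 25000 nM in this assay. For compound 2 `CCN(CC)CCCn1c(=O)c(=Cc2cc(OC)c(OC)c(OC)c2)s/c1=C1\C(=O)Nc2ccc(C)cc21` the result in this assay is only a limit, > 200000 nM. That limit is where compound 2 sits (the limit of > 200000 nM in this assay, at which 1 of the 3 values shown sits). Compound 4 `CCN(CC)CCCn1c(=O)c(=Cc2ccccc2O)s/c1=C1\C(=O)Nc2ccc(C)cc21` keeps the rest of compound 2 and carries 2-hydroxyphenyl in place of 3,4,5-trimethoxyphenyl on a double-bonded chain carbon bound to an aromatic carbon. Within the data shown here, compound 2 stands at a limit, so the size of this step cannot be read from the numbers, and no measured pair speaks to it. Compound 4 is expected to remain weak, at about 100000 nM with a likely range from 20000 nM to 300000 nM, which means an expected step of an at least 2.0-fold lower number from compound 2 to compound 4 (0.30 log units; that floor lies within the scatter).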

Compound 4, half-maximal inhibitory concentration: 15900 nM
Compound 4: middle estimate off by 6.3-fold (0.80 log units), on the high side; measured number outside the range, below it.
By their numbers in this assay, from the lowest: compound 1; then compounds 4 and 3 (each within the scatter of the next). At a limit, above all of these: compound 2.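

At this position, on a double-bonded chain carbon bound to an aromatic carbon, the aryl group can change the result in this assay: replacing 3,4,5-trimethoxyphenyl with 2-hydroxyphenyl gives an at least 12-fold lower number from compound 2 to compound 4 (1.09 log units; beyond the scatter). The rest of compound 2 stays unchanged, so this step belongs to this one place. The number for compound 2 is a limit, not a measured value: the limit of > 200000 nM in this assay, at which 1 of the 4 values shown sits.

The change makes the group smaller and adds a hydrogen-bond donor at once, and the compounds shown do not separate these two differences. Phenyl or 2-methoxyphenyl at this place would help to tell them apart.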